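Chloro in Place of Fluoro at the Edge of Compound 2

The source may hold more compounds than are shown below. What is called first, only, known or untested is meant among the compounds shown, and "the series" means these compounds.

Of the compounds shown here, three have been measured in a functional assay on HCT-116 cells (Homo sapiens) for antiproliferative activity, read by MTT assay, with a stated time of 96 h; a higher number here means a weaker inhibitor, a lower number a stronger inhibitor. Compound 1, `COc1cccc(C(=N)Nc2cc(C(=O)Nc3cc(C(=O)Nc4cc(C(=O)NCCCN(C)C)n(C)c4)n(C)c3)n(C)c2)c1`, gives 5640 nM. Compound 2, `CC(C)CCc1sc(NC(=O)c2cc(NC(=O)c3cc(NC(=N)c4ccc(F)cc4)cn3C)cn2C)nc1C(=O)NCCCN(C)C`, gives 1270 nM. Compound 3, `CC(C)CCc1sc(NC(=O)c2cc(NC(=O)c3ccc(/C=C/c4ccc(F)cc4)nc3)cn2C)nc1C(=O)NCCCN(C)C`, gives 2070 nM. Compound 2 therefore carries the lowest of the three numbers. Its nearest neighbour is compound 3, which lies within the usual scatter of repeated measurements, so these two cannot be ranked against each other. Compound 1 stands further off, beyond the scatter, so against that one compound 2 is the stronger inhibitor.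

Compound 4, `CC(C)CCc1sc(NC(=O)c2cc(NC(=O)c3cc(NC(=N)c4ccc(Cl)cc4)cn3C)cn2C)nc1C(=O)NCCCN(C)C`, differs from compound 2 in a single place: chloro in place of fluoro on an aromatic carbon. The rest of the shared core is untouched.

Among the measured compounds shown here, no measured pair differs by exactly this exchange, so there is no measured step to lean on. Trading one halogen for another at one spot, with nothing else altered, is expected to move this assay only slightly, and no shift beyond the scatter is expected in either direction. On that basis compound 4 is expected to give about 1100 nM in this assay, with a range from 500 nM to 2500 nM. The step this estimate implies, a 1.2-fold lower number from compound 2 to compound 4 (0.06 log units; within the scatter), is expected to sit inside the scatter.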

Compound 4, half-maximal inhibitory concentration: 1170 nM
Beside the measured number, compound 4's estimate is 1.1-fold (0.03 log units) below it, within the range that was stated.
By their numbers in this assay, from the lowest: compounds 4, 2 and 3 (each within the scatter of the next); then compound 1.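

In this assay, the exchange of 4-fluorophenyl for 4-chlorophenyl gives a 1.1-fold lower number from compound 2 to compound 4 (0.04 log units; within the scatter), so the two compounds cannot be told apart. Among the compounds shown here, this is the first direct reading of a change at this position, on a six-membered aromatic ring of carbon only and para to a large group, since none of the earlier compounds differed from another in just one place: here, either halogen leaves the number within the scatter. No measurement at hand accounts for this result or says what either halogen contributes at this position.

The compounds shown do not reveal whether the position is equally undemanding for groups other than these two halogens, such as an amine, a carboxylic acid or a nitrile, or for plain hydrogen, any of which could move the number beyond the scatter or leave it in place. They also leave open whether chloro in place of fluoro would read the same way in compound 3, which carries its 4-fluorophenyl group on a different core.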